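Swapping a bicyclic thioether for a methylpiperazine

This account rests on a few compounds, and the source may have more. Where it says the series, first, only, none or still open, it means among the compounds named here.

In a functional assay on HT-29 cells (Homo sapiens) for cytotoxicity, read by MTT assay, with a stated time of 24 h, tested at 32 ug/mL (a lower number here means a weaker effect, a higher number a stronger effect of the compound at the concentration tested), compound 2 `Cn1c(-c2ccc(NC(=O)CSc3nc4ccccc4s3)cc2)nc(-c2ccccc2)c1-c1ccccc1` gives 66%, the higher of the two numbers recorded, though the step of a number 6.5 percentage points higher from compound 1 to compound 2 (within the scatter) from compound 1 `Cc1ccc2oc(SCC(=O)Nc3ccc(-c4nc(-c5ccccc5)c(-c5ccccc5)n4C)cc3)nc2c1`, which gives 59.5%, stays within the scatter. Compound 3 `CN1CCN(CC(=O)Nc2ccc(-c3nc(-c4ccccc4)c(-c4ccccc4)n3C)cc2)CC1` has not yet been measured. It differs from compound 2 by 4-methylpiperazin-1-yl in place of (1,3-benzothiazol-2-yl)sulfanyl on a saturated chain carbon bound to a carbonyl carbon. Among the compounds with values here, the one measured step changed only the ring bound to the sulfur, whereas here the entire (1,3-benzothiazol-2-yl)sulfanyl part leaves, so no measured step bears directly on this change. Compound 3 is therefore expected to give 40%, with a range from 15% to 65%. The expected step is a number 26 percentage points lower from compound 2 to compound 3 (beyond the scatter), toward a weaker effect.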

Compound 3, a percentage reported as activity, at one concentration (the size of the read-out at that concentration, not a potency): 49.1%
Beside the measured number, compound 3's estimate is 9.1 percentage points below it; the measured number falls inside the stated range.
By their numbers in this assay, from the lowest: compound 3; then compounds 1 and 2 (each within the scatter of the next).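

Replacing the whole (1,3-benzothiazol-2-yl)sulfanyl group with 4-methylpiperazin-1-yl on a saturated chain carbon bound to a carbonyl carbon gives a number 16.9 percentage points lower from compound 2 to compound 3 (beyond the scatter) in this assay, and replacing (5-methyl-1,3-benzoxazol-2-yl)sulfanyl in the same way gives a number 10.4 percentage points lower from compound 1 to compound 3 (beyond the scatter). So this position responds to a change of the whole group, whereas changing only the ring on the sulfur stayed within the scatter. Nothing measured explains the lower number.

From the compounds shown here alone, whether the sulfur, the aromatic rings or the incoming 4-methylpiperazin-1-yl sets this number remains open. A phenylsulfanyl group or a morpholine at this place could help separate these parts.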